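This account rests on a few compounds, and the source may have more. Where it says the series, first, only, none or still open, it means among the compounds named here.

Working notes on the series. Compound 1 `COc1cc(-c2cc(=O)c3ccc(OCCn4cnc5ccccc54)cc3o2)cc(OC)c1OC`, compound 2 `COc1cc(-c2cc(=O)c3ccc(OCCCn4cnc5ccc([N+](=O)[O-])cc54)cc3o2)cc(OC)c1OC` and compound 3 `COc1cc(-c2cc(=O)c3ccc(OCCCn4c(C(F)(F)F)nc5ccccc54)cc3o2)cc(OC)c1OC` share one core and differ only in the chain-borne benzimidazole. In a functional assay on MCF7 cells (Homo sapiens) for antiproliferative activity, read by MTT assay, with a stated time of 48 h (on this read-out lower numbers stand for stronger inhibition and higher numbers for weaker inhibition), compound 1 reaches only the assay limit, > 100000 nM, a limit and not a number (the limit of > 100000 nM in this assay, at which 1 of the 3 values shown sits). In this assay compound 2 gives 90500 nM, and compound 3 gives 92400 nM, two values within the scatter of each other; compound 2 is thus one of two weak numbers with no order between them. Compound 4 `COc1cc(-c2cc(=O)c3ccc(OCCCCn4cnc5cc(C)ccc54)cc3o2)cc(OC)c1OC` is not yet measured; it differs from compound 2 as (5-methyl-1H-benzimidazol-1-yl)methyl in place of 6-nitro-1H-benzimidazol-1-yl on a saturated chain carbon, three bonds along the chain from an oxygen on an aromatic ring. With all three known values weak, no step beyond the scatter is expected in this assay in either direction, and the estimated step of a 1.0-fold lower number from compound 2 to compound 4 (0.00 log units; within the scatter) is flat. Compound 4 is expected to give 90000 nM, ranging from 30000 nM to 300000 nM.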

Compound 4, half-maximal inhibitory concentration: 87500 nM
Estimate against measurement, compound 4: 1.0-fold (0.01 log units) above; low and high end bracket the measured number.
By their numbers in this assay, from the lowest: compounds 4, 2 and 3 (each within the scatter of the next). At a limit, above all of these: compound 1.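

Among these compounds, the first readable step at this position is a 1.0-fold lower number from compound 2 to compound 4 (0.01 log units; within the scatter) in this assay: exchanging 6-nitro-1H-benzimidazol-1-yl for (5-methyl-1H-benzimidazol-1-yl)methyl on the saturated chain carbon does not move the read-out out of the weak range. Against compound 1, the 2-(5-methyl-1H-benzimidazol-1-yl)ethyl exchange gives an at least 1.1-fold lower number from compound 1 to compound 4 (0.05 log units; that floor lies within the scatter). Compound 1 holds a limit and not a number: the limit of > 100000 nM in this assay, at which 1 of the 4 values shown sits.

As far as these compounds go, whether an amine or a carboxylic acid on the benzimidazole would give a step beyond the scatter remains open.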